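Working notes: 2-fluorobenzyl to 4-fluorobenzyl

The compounds below may be only part of what the source reports. "The series", "measured", "known", "first", "only" and "open" are said of these compounds alone.

- Compound 1 `COc1cccc(C(=O)Oc2ccc3c(=O)c(-c4cc(OC)c(OC)cc4OC)coc3c2)c1` gives > 10000 nM in a functional assay on HCT-116 cells (Homo sapiens) for antiproliferative activity, read by MTT assay, with a stated time of 24 h (on this read-out lower numbers stand for stronger inhibition and higher numbers for weaker inhibition), a limit and not a number
- Compound 2 `COc1cc(OC)c(-c2coc3cc(OCc4ccccc4F)ccc3c2=O)cc1OC` gives 2900 nM in this assay
- Compound 3 `COc1cc(OC)c(-c2coc3cc(OCc4ccc(F)cc4)ccc3c2=O)cc1OC` is not yet measured

In this assay, within the data shown here, compound 2 holds the only number so far, since the other result is a limit. The next change is 4-fluorophenyl in place of 2-fluorophenyl on a saturated chain carbon bound to an oxygen on an aromatic ring, with 4-fluorophenyl in place of 2-fluorophenyl on a saturated chain carbon bound to an oxygen on an aromatic ring. Among the measured compounds shown here, one measured step bears on this site: an at least 3.4-fold lower number from compound 1 to compound 2 (0.53 log units; beyond the scatter). It lies beyond the scatter, but it replaces a different group and gives no size for this exchange. No direction can be drawn from it, so the expectation is a 1.0-fold lower number from compound 2 to compound 3 (0.02 log units; within the scatter), probably within the scatter. Compound 3 is estimated at 2800 nM, with an expected range of 800 nM to 9000 nM.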

Compound 3, half-maximal inhibitory concentration: 950 nM
For compound 3 the middle estimate is 2.9-fold (0.47 log units) above the measured one; the measured number falls inside the stated range.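

In this assay, 4-fluorophenyl in place of 2-fluorophenyl on the saturated chain carbon gives a 3.1-fold lower number from compound 2 to compound 3 (0.48 log units; beyond the scatter). The earlier step exchanged the whole group on the oxygen, whereas this one shows that moving from 2-fluorobenzyl to 4-fluorobenzyl, with the same atoms joined differently, is enough on its own to shift the number beyond the scatter. With 4-fluorobenzyl in place of (3-methoxyphenyl)carbonyl the change reaches an at least 10-fold lower number from compound 1 to compound 3 (1.02 log units; beyond the scatter), a size that rests on a limit and not on a number: the limit of > 10000 nM in this assay, at which 1 of the 3 values shown sits.

The compounds shown leave open what an unsubstituted benzyl group, a 4-chlorobenzyl group or a longer chain between the oxygen and the aromatic ring would give. Going by these compounds, whether the gain from 4-fluorobenzyl carries over to other cell lines or other exposure times also remains open.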